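The source may hold more compounds than are shown below. What is called first, only, known or untested is meant among the compounds shown, and "the series" means these compounds.

Measured compounds:
Compound 1: `Cc1c(F)cccc1CCCCOc1ccc(/C=C/c2cccc3c(CCCC(=O)O)c(C)n(CC(=O)O)c23)cc1`; in a functional assay on the whole organism for inhibition, with Cavia porcellus as the target, with stated times of 1 h and 10 min, at a dose of 1 mg/kg by the oral route (a lower number here means a weaker effect, a higher number a stronger effect of the compound at the dose given), compound 1 gives 94%.
Compound 2: `O=C(O)CCCc1cn(CC(=O)O)c2c(/C=C/c3ccc(OCCCCOc4ccccc4)cc3)cccc12`; in this assay compound 2 gives 97%.

Compound 2 and compound 1 give numbers that lie within the usual scatter of each other, both close to complete inhibition at the dose given, so neither can be set above the other on these two results. Going by the values given here, no step between measured compounds that differ in one place is available, and nothing beyond these two numbers describes the series.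

Compound 3, `O=C(O)CCCc1cn(CC(=O)O)c2c(/C=C/c3ccc(OCCCCc4c(F)ccc(F)c4F)cc3)cccc12`, is not yet measured. It departs from compound 2 by one change: 2,3,6-trifluorophenyl in place of phenoxy on a saturated chain carbon, four bonds along the chain from an oxygen on an aromatic ring. Among the compounds with values here, compound 1 carries a related fluorine-bearing ring at the end of the same chain and still sits near the top of the scale, which is the only guide here. On that basis the step of a number 7 percentage points lower from compound 2 to compound 3 (within the scatter) is expected to be small, in the downward direction if anything, and not clearly beyond the scatter. Compound 3 is therefore estimated to give 90% in this assay, within a range from 70% to 98%.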

Compound 3, a percentage reported as inhibition, in the whole organism at one dose (the size of the read-out at that dose, not a potency): 94%
For compound 3 the middle estimate is 4 percentage points below the measured one; the range from low to high includes it.
By their numbers in this assay, from the lowest: compounds 1, 3 and 2 (each within the scatter of the next).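

Going by these compounds alone, the step of a number 3 percentage points lower from compound 2 to compound 3 (within the scatter) is the first comparison in this assay between compounds that differ in one place, and it isolates the group on a saturated chain carbon, four bonds along the chain from an oxygen on an aromatic ring. Compound 1 could not show this, since it differs from compound 2 in more than one place. The step shows that at the dose given, this place accepts 2,3,6-trifluorophenyl in place of phenoxy without a difference beyond the scatter, even though the oxygen of phenoxy is gone and the entering group has more heavy atoms, so neither that oxygen nor an unsubstituted ring is needed for a number near the top of the scale.

The compounds shown leave open whether an amine or a shorter chain at this place would also keep the number near the top of the scale, and a single dose with all numbers so high cannot tell how far the compounds differ in potency. No measured property of either group is at hand to bear on this result.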